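Changing the Aromatic Group on the Amide Carbonyl

The compounds below may be only part of what the source reports. "The series", "measured", "known", "first", "only" and "open" are said of these compounds alone.

Three compounds share one core and differ only in the aromatic group joined to a carbonyl carbon. In a functional assay on the whole organism (blood) with Rattus norvegicus as the target, with stated times of 24 h and 1 h, at a dose of 5 mg/kg by the intraperitoneal route (a higher number here means a stronger effect of the compound at the dose given, a lower number a weaker effect), compound 1 `COc1ccncc1C(=O)NCCC1CCN(S(=O)(=O)NC(=O)NC[C@@H]2C[C@@H]3C=C[C@@H]2C3)CC1` gives 14%. Compound 2 `O=C(NC[C@@H]1C[C@@H]2C=C[C@@H]1C2)NS(=O)(=O)N1CCC(CCNC(=O)c2ccc3ccccc3n2)CC1` gives 21% in this assay, and compound 3 `COc1ccc2nccc(C(=O)NCCC3CCN(S(=O)(=O)NC(=O)NC[C@@H]4C[C@@H]5C=C[C@@H]4C5)CC3)c2c1` gives 10% in this assay. Compound 3 therefore holds the lowest of the three numbers: its gap to compound 1, seen in the step of a number 4 percentage points lower from compound 1 to compound 3 (within the scatter), is within the scatter, whereas the step of a number 11 percentage points lower from compound 2 to compound 3 (beyond the scatter) lies beyond it.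

Compound 4 `O=C(NC[C@@H]1C[C@@H]2C=C[C@@H]1C2)NS(=O)(=O)N1CCC(CCNC(=O)c2cc(Cl)cc3cccnc23)CC1` is the next compound to be measured. 6-chloroquinolin-8-yl in place of 6-methoxyquinolin-4-yl on a carbonyl carbon The change again sits on the carbonyl carbon whose other neighbour is an amide-type nitrogen, the same place that was varied among the first three compounds. Among the compounds with values here, the steps that bear on it are a number 7 percentage points higher from compound 1 to compound 2 (within the scatter), a number 4 percentage points lower from compound 1 to compound 3 (within the scatter) and a number 11 percentage points lower from compound 2 to compound 3 (beyond the scatter); two of them stayed within the scatter and the third was only modest. Within the data shown here, no measured step involves a chlorine-bearing group, so the direction is open. The step of a number 5 percentage points higher from compound 3 to compound 4 (within the scatter) is expected to remain within the scatter, or to be modest at most. Compound 4 is estimated to give 15% in this assay, with a range from 5% to 28%.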

Compound 4, a percentage reported as activity, at one dose (the size of the read-out at that dose, not a potency): 35%
Compound 4: middle estimate off by 20 percentage points, on the low side; the measured number lies above the stated range.
By their numbers in this assay, from the lowest: compounds 3, 1 and 2 (each within the scatter of the next, the first and the last beyond it); then compound 4.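

In this assay the 6-chloroquinolin-8-yl group stands clearly above all three earlier groups, with the steps of a number 25 percentage points higher from compound 3 to compound 4 (beyond the scatter) and a number 14 percentage points higher from compound 2 to compound 4 (beyond the scatter) and also a number 21 percentage points higher from compound 1 to compound 4 (beyond the scatter) on the same carbonyl carbon. Within the data shown here, the earlier compounds gave only one step beyond the scatter at this place, so compound 4 shows that the aromatic group here can move the number further than they suggested, and it holds the highest number of the four. No measurement shown here explains why this group gives the higher number.

Compared with compound 3, compound 4 has a chlorine instead of a methoxy group, and its bicyclic group is joined to the carbonyl carbon through the 8-yl rather than the 4-yl attachment, so these two differences cannot be separated. A plain quinolin-8-yl group without the chlorine, or a 6-fluoroquinolin-8-yl or 6-bromoquinolin-8-yl group, would be needed to tell whether the chlorine atom itself matters or whether the attachment accounts for the rise.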